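This account rests on a few compounds, and the source may have more. Where it says the series, first, only, none or still open, it means among the compounds named here.

Of the compounds shown here, two have so far been tested in a functional assay on A549 cells (Homo sapiens) for cytotoxicity, read by MTT assay, with a stated time of 24 h; on this read-out higher numbers stand for weaker inhibition and lower numbers for stronger inhibition. Compound 1 `Cc1cc(-c2nc3cc(Cl)ccc3o2)ccc1NC(=O)CCl` gives 91500 nM, the highest of the two numbers; compound 2 `O=C(CCl)Nc1ccc(-c2nc3cc(F)ccc3o2)cc1` gives 37700 nM, a gap that lies beyond the scatter. Compound 3 `Cc1ccc2oc(-c3ccc(NC(=O)CCl)c(C)c3)nc2c1` awaits measurement in this assay. It differs from compound 1 by methyl in place of chloro on an aromatic carbon. For the measured compounds named here, no measured pair shows this change, so the step is expected to be small, in either direction or none beyond the scatter, as a 1.1-fold lower number from compound 1 to compound 3 (0.06 log units; within the scatter). Compound 3 is therefore estimated at 80000 nM, with a range from 30000 nM to 200000 nM.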

Compound 3, half-maximal inhibitory concentration: 61800 nM
Estimate against measurement, compound 3: 1.3-fold (0.11 log units) above; the range from low to high includes it.
By their numbers in this assay, from the lowest: compounds 2, 3 and 1 (each within the scatter of the next, the first and the last beyond it).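

In this assay, putting methyl in place of chloro on an aromatic carbon gives a 1.5-fold lower number from compound 1 to compound 3 (0.17 log units; within the scatter) and so provides the first step read at this position. On this single pair, the position takes either group without a change beyond the scatter. Nothing available explains the size of this step. The compounds shown leave open how an amine, a methoxy group or a carboxylic acid would read at this position. They also leave open whether the same change would read alike on the core of compound 2.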